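The compounds below may be only part of what the source reports. "The series", "measured", "known", "first", "only" and "open" are said of these compounds alone.

Compound 1 `Cn1c(/C=C2\SC(=O)N(CC(=O)N3CCCCC3)C2=O)nc2ccccc21` carries the shared core with a methyl on the aromatic nitrogen and a piperidin-1-yl amide. In a functional assay on A549 cells (Homo sapiens) for inhibition, read by MTT assay, with a stated time of 48 h (on this read-out lower numbers stand for stronger inhibition and higher numbers for weaker inhibition), compound 1 reaches only the limit of the assay, > 50000 nM. Compound 2 `CC(C)n1c(/C=C2\SC(=O)N(CC(=O)N3CCCCC3)C2=O)nc2ccccc21` gives 28200 nM in this assay, and compound 3 `CC1CN(C(=O)CN2C(=O)S/C(=C\c3nc4ccccc4n3C)C2=O)CC(C)O1` gives 29400 nM there. The change from compound 1 to compound 2 is isopropyl in place of methyl on an aromatic nitrogen; it produced an at least 1.7-fold lower number from compound 1 to compound 2 (0.24 log units; that floor lies within the scatter), which is a floor only because compound 1 sits at the limit of > 50000 nM in this assay, at which 1 of the 3 values shown sits. The two cores differ by 2,6-dimethylmorpholin-4-yl in place of piperidin-1-yl on a carbonyl carbon, and that change produced an at least 1.7-fold lower number from compound 1 to compound 3 (0.23 log units; that floor lies within the scatter). Compound 2 and compound 3 lie within the scatter of each other. Compound 4 `CC1CN(C(=O)CN2C(=O)S/C(=C\c3nc4ccccc4n3C(C)C)C2=O)CC(C)O1` is not yet measured in this assay. It differs from compound 3 by isopropyl in place of methyl on an aromatic nitrogen, the same change as that from compound 1 to compound 2, made at a place described in the same words. The size of that earlier step is known only as a floor, the value of compound 1 being a limit. In this assay a step of a 1.7-fold lower number from compound 3 to compound 4 (0.24 log units; within the scatter) is expected, resting on an at least 1.7-fold lower number from compound 1 to compound 2 (0.24 log units; that floor lies within the scatter). Compound 4 is thus estimated at 17000 nM in this assay, with a likely range from 7000 nM to 40000 nM.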

Compound 4, half-maximal inhibitory concentration: > 50000 nM
Compound 4: no number, only a limit; the forecaster's own chance of this, stated with the estimate: 10%; middle value at least 2.9-fold (0.46 log units) away from the limit.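

In this assay, isopropyl in place of methyl on an aromatic nitrogen gave an at least 1.7-fold higher number from compound 3 to compound 4 (0.23 log units; that floor lies within the scatter) with the 2,6-dimethylmorpholin-4-yl amide, the opposite direction to that seen with the piperidin-1-yl amide, so this change does not carry from one core to the other in these four compounds: the same change on two cores in this assay, an at least 1.7-fold lower number (0.24 log units; that floor lies within the scatter) from compound 1 to compound 2 and an at least 1.7-fold higher number (0.23 log units; that floor lies within the scatter) from compound 3 to compound 4, at least 3.0-fold (0.47 log units) apart, beyond the scatter of two such steps

The amide change likewise gave an at least 1.7-fold higher number from compound 2 to compound 4 (0.24 log units; that floor lies within the scatter) with isopropyl on the aromatic nitrogen, against its direction with methyl there: the same change on two cores in this assay, an at least 1.7-fold lower number (0.23 log units; that floor lies within the scatter) from compound 1 to compound 3 and an at least 1.7-fold higher number (0.24 log units; that floor lies within the scatter) from compound 2 to compound 4, at least 3.0-fold (0.47 log units) apart, beyond the scatter of two such steps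

The reversal is shown in direction only; the true sizes of these steps cannot be read, and nothing here explains the reversal, as compound 1 and compound 4 are both limits and not numbers: the limit of > 50000 nM in this assay, at which 2 of the 4 values shown sit.

Open, from the compounds shown here alone, is whether the reversal persists with an intermediate group on the aromatic nitrogen, such as ethyl, or with another amine in the amide, such as pyrrolidine or unsubstituted morpholine. Also open, going by these compounds, is whether any such pairing moves the series clear of the assay limit.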